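The source may report more compounds than this note shows. Statements on the series, on what has been measured and on what is new or still open speak of the compounds shown alone.

Within the data shown here, compound 2 `CC(O)c1cn(CCNc2nonc2/C(=N/O)Nc2ccc(F)c(Br)c2)nn1` gives 362 nM in an assay on isolated protein for inhibition of Indoleamine 2,3-dioxygenase 2 (Homo sapiens) (on this read-out higher numbers stand for weaker inhibition and lower numbers for stronger inhibition), the lower of the two numbers measured so far. Compound 1 `CC(C)(C)c1cn(CCNc2nonc2/C(=N/O)Nc2ccc(F)c(Br)c2)nn1` gives 1870 nM in this assay. The step of a 5.2-fold lower number from compound 1 to compound 2 (0.71 log units; beyond the scatter) came with 1-hydroxyethyl in place of tert-butyl on an aromatic carbon. Compound 3 `CCC(C)(O)c1cn(CCNc2nonc2/C(=N/O)Nc2ccc(F)c(Br)c2)nn1` has not yet been measured. It differs from compound 2 by ethyl in place of hydrogen on a saturated chain carbon bound to an aromatic carbon, an oxygen on a saturated carbon and a saturated chain carbon. Among the measured compounds shown here, the only measured step that bears on this change is a 5.2-fold lower number from compound 1 to compound 2 (0.71 log units; beyond the scatter), which replaced a group without a hydroxyl by one carrying it; compound 3 keeps that hydroxyl and only gains an ethyl, so the earlier step informs the outcome only in part. For compound 3 a slight weakening in this assay, possibly none beyond the scatter, is expected, amounting to an estimated step of a 1.7-fold higher number from compound 2 to compound 3 (0.22 log units; within the scatter). Compound 3 is therefore expected to give about 600 nM in this assay, with a range from 250 nM to 1500 nM.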

Compound 3, half-maximal inhibitory concentration: 958 nM
Compound 3: the middle estimate sits 1.6-fold (0.20 log units) below what was measured; the measured number falls inside the stated range.
By their numbers in this assay, from the lowest: compound 2; then compounds 3 and 1 (each within the scatter of the next).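

In this assay, going from 1-hydroxyethyl to 1-hydroxy-1-methylpropyl gives a 2.6-fold higher number from compound 2 to compound 3 (0.42 log units; beyond the scatter), so at this position carrying a hydroxyl is not enough to hold the better number: the added ethyl on that same chain carbon gives part of it back. The second comparison, a 2.0-fold lower number from compound 1 to compound 3 (0.29 log units; within the scatter), leaves the 1-hydroxy-1-methylpropyl and tert-butyl groups indistinguishable here, whereas the earlier 5.2-fold lower number from compound 1 to compound 2 (0.71 log units; beyond the scatter) separated 1-hydroxyethyl from tert-butyl clearly. Nothing available explains this effect of the ethyl group.

The compounds shown leave open how a hydroxymethyl group would read at this position, and whether a further trimming of the chain would lower the number again. They also leave open whether the hydroxyl itself is needed, which a 1-methoxyethyl group or an amine such as 1-aminoethyl would test.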